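A few compounds are considered here, and "the series" means these few. Any claim that something is new, unique, unknown or untested is made for them only; others in the source may bear on it.

In a functional assay on NCI-H460 cells (Homo sapiens) for antiproliferative activity, read by sulforhodamine B assay, with a stated time of 72 h (a higher number here means a weaker inhibitor, a lower number a stronger inhibitor), compound 3 `CN(CCNCc1cn(Cc2ccc(Br)cc2)nn1)CCNc1ccnc2cc(Cl)ccc12` gives 12000 nM, the lowest of the three numbers in hand, though compound 1 `CN(CCNCc1cn(-c2ccc(Cl)cc2)nn1)CCNc1ccnc2cc(Cl)ccc12` at 14000 nM and compound 2 `CN(CCNCc1cn(-c2cccc(Cl)c2)nn1)CCNc1ccnc2cc(Cl)ccc12` at 17000 nM both lie within the scatter of it. Compound 4 `CN(CCNCc1cn(Cc2nc3ccccc3[nH]2)nn1)CCNc1ccnc2cc(Cl)ccc12` differs from compound 3 by 1H-benzimidazol-2-yl in place of 4-bromophenyl on a saturated chain carbon bound to an aromatic nitrogen. Earlier exchanges at this same aromatic nitrogen carried no signal: a 1.2-fold lower number from compound 1 to compound 3 (0.07 log units; within the scatter) and a 1.4-fold lower number from compound 2 to compound 3 (0.15 log units; within the scatter), while a 1.2-fold higher number from compound 1 to compound 2 (0.08 log units; within the scatter). None of those exchanges brought in a hydrogen-bond donor or acceptor, so the present change is not covered by any measured step. With no sign of sensitivity at this position, the expected step is no change at the digits printed from compound 3 to compound 4 (within the scatter), nothing beyond the scatter. Compound 4 is accordingly estimated at 12000 nM, with a range of 5000 nM to 30000 nM.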

Compound 4, half-maximal inhibitory concentration: 120000 nM
Beside the measured number, compound 4's estimate is 10-fold (1.00 log units) below it; measured number outside the range, above it.
By their numbers in this assay, from the lowest: compounds 3, 1 and 2 (each within the scatter of the next); then compound 4.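

In this assay, going by these compounds alone, the substituent on the aromatic nitrogen is not indifferent after all: a 10-fold higher number from compound 3 to compound 4 (1.00 log units; beyond the scatter) with 1H-benzimidazol-2-yl in place of 4-bromophenyl, the first step beyond the scatter. Measured against the two chlorophenyl compounds, (1H-benzimidazol-2-yl)methyl also gives a 7.1-fold higher number from compound 2 to compound 4 (0.85 log units; beyond the scatter) and an 8.6-fold higher number from compound 1 to compound 4 (0.93 log units; beyond the scatter) in the same direction. Nothing available explains these steps.

From the compounds shown here alone, compound 4 changes ring size, ring nitrogens and hydrogen-bond count together, so which of these matters stays open. Going by these compounds, how a 1-methyl-1H-benzimidazol-2-yl or a naphthyl group would read on that saturated chain carbon also remains open.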